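Swapping the ester side chain of a dihydropyridine

The source may hold more compounds than are shown below. What is called first, only, known or untested is meant among the compounds shown, and "the series" means these compounds.

Of the compounds shown here, two have been measured in a functional assay on HEK293 cells for antagonist activity at Voltage-dependent L-type calcium channel subunit alpha-1D (Rattus norvegicus), read by FLIPR; a lower number here means a stronger inhibitor, a higher number a weaker inhibitor. Compound 1 `C#CCCOC(=O)C1=C(C)NC(C)=C(C(=O)OC)C1c1cccc([N+](=O)[O-])c1` gives 35 nM, and compound 2 `COC(=O)C1=C(C)NC(C)=C(C(=O)OCCc2ccc(Cl)cc2)C1c1cccc([N+](=O)[O-])c1` gives 39 nM. Compound 2 has the higher of the two numbers, but its nearest neighbour, compound 1, lies within the scatter of it; the step of a 1.1-fold higher number from compound 1 to compound 2 (0.05 log units; within the scatter) shows that this change on the ester side chain made no difference beyond the scatter.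

Compound 3 `COC(=O)C1=C(C)NC(C)=C(C(=O)OCc2ccc(-c3ccccc3)cc2)C1c1cccc([N+](=O)[O-])c1` has not yet been measured. It differs from compound 2 by 4-phenylphenyl in place of 4-chlorobenzyl on a saturated chain carbon bound to an oxygen next to a carbonyl group. For the measured compounds named here, the only step that bears on this change is the one from compound 1 to compound 2, which also swapped the group carried on the ester side chain and stayed within the scatter. A similar outcome is therefore expected here: in this assay compound 3 is estimated at 45 nM, with a plausible range from 15 nM to 150 nM, which corresponds to an expected step of a 1.2-fold higher number from compound 2 to compound 3 (0.06 log units; within the scatter).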

Compound 3, half-maximal inhibitory concentration: 74 nM
The estimate for compound 3 lay 1.6-fold (0.22 log units) below the measured number, within the range that was stated.
By their numbers in this assay, from the lowest: compounds 1, 2 and 3 (each within the scatter of the next, the first and the last beyond it).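

In this assay, putting 4-phenylphenyl, with two aromatic rings, in place of 4-chlorobenzyl, with one, gives a 1.9-fold higher number from compound 2 to compound 3 (0.28 log units; within the scatter), so even this change of ring count on the saturated chain carbon stays within the scatter. Set against propargyl, the same group gives a 2.1-fold higher number from compound 1 to compound 3 (0.33 log units; beyond the scatter), the first step among these compounds to pass beyond the scatter, and only a modest one, so all three side chains remain fairly close together. No supporting data are available to explain this small spread.

As far as these compounds go, it remains open whether a side chain carrying an amine or a carboxylic acid would stay this close to the others. It is also unknown whether a longer chain carrying the 4-phenylphenyl group would widen the gap.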